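A few compounds are considered here, and "the series" means these few. Any claim that something is new, unique, unknown or untested is made for them only; others in the source may bear on it.

Three related compounds have been tested in an ADME assay on the whole organism for inhibition, with Oryza sativa as the target, with a stated time of 4 days (on this read-out higher numbers stand for weaker inhibition and lower numbers for stronger inhibition), all sharing one core and differing only in one amine attached to it. Compound 1 `CCNc1nc(Cl)nc(N[C@H](C)c2ccccc2)n1` gives 14100 nM. Compound 2 `CC[C@H](C)Nc1nc(Cl)nc(N[C@@H](C)c2ccccc2)n1` gives 6920 nM, and compound 3 `CC[C@@H](C)Nc1nc(Cl)nc(N[C@H](C)c2ccccc2)n1` gives 8320 nM. Compound 2 has the lowest of the three numbers, but its nearest neighbour is compound 3, and the pair lie within the usual scatter of repeated measurements; only compound 1 sits beyond the scatter from compound 2.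

Two single-point steps have been measured. Going from compound 1 to compound 3 adds ethyl on a saturated chain carbon bound to a nitrogen on an aromatic ring and a saturated chain carbon, and the result is a 1.7-fold lower number from compound 1 to compound 3 (0.23 log units; within the scatter). Going from compound 2 to compound 3 inverts both stereocentres, (the fact that compounds 2 and 3 differ only in the configuration as drawn), and the result is a 1.2-fold higher number from compound 2 to compound 3 (0.08 log units; within the scatter). Neither step moved this assay meaningfully.

The next compound, compound 4 `CCN(CC)c1nc(Cl)nc(N[C@@H](C)c2ccccc2)n1`, changes compound 2 as follows: diethylamino in place of (sec-butyl)amino on an aromatic carbon. This change removes the hydrogen-bond donor that the measured steps all kept, so they offer no direct guide. A weaker inhibitor, that is a higher number, is expected, with the step of a 2.9-fold higher number from compound 2 to compound 4 (0.46 log units; beyond the scatter). Compound 4 is estimated at 20000 nM, with a range from 8000 nM to 60000 nM.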

Compound 4, half-maximal inhibitory concentration: 380 nM
Compound 4: the middle estimate sits 53-fold (1.72 log units) above what was measured; the measured number lies below the stated range.
By their numbers in this assay, from the lowest: compound 4; then compounds 2, 3 and 1 (each within the scatter of the next, the first and the last beyond it).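

In this assay, going by these compounds alone, exchanging (sec-butyl)amino for diethylamino on this aromatic carbon gives an 18-fold lower number from compound 2 to compound 4 (1.26 log units; beyond the scatter) and is the first step here to lie beyond the scatter, whereas a 1.7-fold lower number from compound 1 to compound 3 (0.23 log units; within the scatter) and a 1.2-fold higher number from compound 2 to compound 3 (0.08 log units; within the scatter) both stay within it. The two groups have the same heavy atoms, joined differently, so at this place the way the amine is put together matters in this assay, and not just how many atoms it carries. Within the data shown here, the one change takes away the hydrogen-bond donor and the defined stereocentre of the leaving group together, and nothing given here explains the step or separates those two differences.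

Whether the lower number follows from the lost hydrogen-bond donor or from the two ethyl chains themselves stays open, since compound 4 is the only compound shown with no donor on this amine. Dimethylamino or dipropylamino at this place would show whether the effect holds for shorter or longer chains, and a compound with the other amine of compound 4 in its mirror-image form would test whether it depends on that configuration.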